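Sulfone to Sulfoxide on the Saturated Ring Carbon

The source may hold more compounds than are shown below. What is called first, only, known or untested is meant among the compounds shown, and "the series" means these compounds.

Compound 1 `COC1(c2cc(F)cc(OCc3ccc(-n4ccnc4C)cc3)c2)CCOCC1`: in an assay on blood for inhibition of Polyunsaturated fatty acid 5-lipoxygenase (Homo sapiens) (on this read-out lower numbers stand for stronger inhibition and higher numbers for weaker inhibition), compound 1 gives 60 nM.
Compound 2 `Cc1nccn1-c1ccc(COc2cc(F)cc(C3(S(C)(=O)=O)CCOCC3)c2)cc1`: in this assay compound 2 gives > 1000 nM, a limit of the assay rather than a number.

Compound 2 therefore stands at the limit of > 1000 nM in this assay, at which 1 of the 2 values shown sits. Compound 3 `Cc1nccn1-c1ccc(COc2cc(F)cc(C3([S+](C)[O-])CCOCC3)c2)cc1` differs from compound 2 in one place: a group of 3 heavy atoms (1 carbon, 1 oxygen, 1 sulfur; no ring) in place of a group of 4 heavy atoms (1 carbon, 2 oxygen, 1 sulfur; no ring), on a saturated ring carbon. Among the compounds with values here, the only measured step that bears on this change is an at least 16-fold higher number from compound 1 to compound 2 (1.22 log units; beyond the scatter), a large loss. The entering group stands between the methoxy of compound 1 and the methylsulfonyl of compound 2 in what it counts, so a partial return toward lower numbers is expected, though with wide uncertainty. Compound 3 is estimated at 600 nM, between 150 nM and 2500 nM, an expected step of an at least 1.6-fold lower number from compound 2 to compound 3 (0.22 log units; that floor lies within the scatter).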

Compound 3, half-maximal inhibitory concentration: > 1000 nM
Compound 3 was reported as a limit; the forecaster's own chance of this, stated with the estimate: 40%; at least 1.6-fold (0.22 log units) between middle value and limit.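

Exchanging the methoxy of compound 1 for the sulfur-bearing group of compound 3 gives an at least 16-fold higher number from compound 1 to compound 3 (1.22 log units; beyond the scatter), so at this saturated ring carbon the loss is not confined to the methylsulfonyl. Compound 2 and compound 3 are each reported only as a limit of the assay, not a number, so the step between them cannot be read: the limit of > 1000 nM in this assay, at which 2 of the 3 values shown sit.

On these data alone, how far past that limit either compound lies stays open. As far as these compounds go, it is also open whether an amine, a hydroxyl or an ethoxy on the same ring carbon would stay close to compound 1 at 60 nM.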